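The source may hold more compounds than are shown below. What is called first, only, known or untested is meant among the compounds shown, and "the series" means these compounds.

Three acylguanidine compounds share one core and were tested in a functional assay on MCF7 cells (Homo sapiens) for inhibition, read by MTT assay, with a stated time of 72 h; a higher number here means a weaker inhibitor of growth, a lower number a stronger inhibitor of growth. Compound 1 `CC(C)=CCC/C(C)=C/C(=O)NC(=N)NC(=O)C=C(C)C` gives 41500 nM, compound 2 `CC(C)=CCC/C(C)=C/C(=O)NC(=N)NC(=O)/C=C(\C)CCC=C(C)C` gives 42400 nM, and compound 3 `CC(C)=CCC/C(C)=C/CC/C(C)=C/C(=O)NC(=N)NC(=O)/C=C(\C)CC/C=C(\C)CCC=C(C)C` gives 30300 nM, which is the lowest of the three numbers, though its gaps to compound 1 and compound 2 both lie within the scatter. Compound 4 `CC(C)=CCC/C(C)=C/CC/C(C)=C/C(=O)NC(=N)NC(=O)/C=C(\C)CCC=C(C)C` differs from compound 3 in one place: hydrogen in place of 3-methylbut-2-en-1-yl on a saturated chain carbon bound to a double-bonded chain carbon. Among the measured compounds shown here, the one measured step of this kind, a 1.0-fold higher number from compound 1 to compound 2 (0.01 log units; within the scatter), ran the other way and stayed within the scatter. The step to compound 4 is therefore expected to be a 1.1-fold higher number from compound 3 to compound 4 (0.05 log units; within the scatter), with no change beyond the scatter. Compound 4 is estimated at 34000 nM, between 17000 nM and 68000 nM.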

Compound 4, concentration for 50% growth inhibition: 51200 nM
The estimate for compound 4 lay 1.5-fold (0.18 log units) below the measured number; the measured number falls inside the stated range.
By their numbers in this assay, from the lowest: compounds 3, 1, 2 and 4 (each within the scatter of the next).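

Swapping 3-methylbut-2-en-1-yl for hydrogen on the larger core of compound 3 gives a 1.7-fold higher number from compound 3 to compound 4 (0.23 log units; within the scatter) in this assay, so this place shows no change beyond the scatter on a second core. Chains added at this kind of place also stay within the scatter: 3-methylbut-2-en-1-yl gives a 1.2-fold higher number from compound 2 to compound 4 (0.08 log units; within the scatter), and 3,7-dimethylocta-2,6-dien-1-yl gives a 1.2-fold higher number from compound 1 to compound 4 (0.09 log units; within the scatter). The two readings of the change agree within the scatter: the same change on two cores in this assay, a 1.0-fold higher number (0.01 log units; within the scatter) from compound 1 to compound 2 and a 1.7-fold lower number (0.23 log units; within the scatter) from compound 4 to compound 3, 1.7-fold (0.24 log units) apart, within the scatter of two such steps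

Every group compared here is hydrogen or a hydrocarbon chain. Going by these compounds, whether an amine or a carboxylic acid at this place would move the number beyond the scatter remains open.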